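Swapping 4-bromobutyl for 4,4-difluorocyclohexyl

This account rests on a few compounds, and the source may have more. Where it says the series, first, only, none or still open, it means among the compounds named here.

Of the compounds shown here, three sharing one core have been tested in a functional assay on A549 cells (Homo sapiens) for cytotoxicity, read by MTT assay, with a stated time of 48 h; a higher number here means a weaker inhibitor, a lower number a stronger inhibitor. Compound 1 (`C=C1C(=O)O[C@H]2CC3=C[C@H](C/C(C)=C/[C@@H](OC(=O)c4ccc(C(F)(F)F)cc4)[C@H]12)OC3=O`) reads > 10000 nM, which is a limit of the assay and not a number. Compound 2 (`C=C1C(=O)O[C@H]2CC3=C[C@H](C/C(C)=C/[C@@H](OC(=O)/C=C/c4ccccc4)[C@H]12)OC3=O`) gives 4800 nM. Compound 3 (`C=C1C(=O)O[C@H]2CC3=C[C@H](C/C(C)=C/[C@@H](OC(=O)CCCCBr)[C@H]12)OC3=O`) reads > 10000 nM, also only a limit. This is the limit of > 10000 nM in this assay, at which 2 of the 3 values shown sit.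

Compound 4 (`C=C1C(=O)O[C@H]2CC3=C[C@H](C/C(C)=C/[C@@H](OC(=O)C4CCC(F)(F)CC4)[C@H]12)OC3=O`) alters compound 3 in one place: 4,4-difluorocyclohexyl in place of 4-bromobutyl on a carbonyl carbon. For the measured compounds named here, no measured step covers this exact swap. The closest guides are an at least 2.0-fold higher number from compound 2 to compound 3 (0.31 log units; beyond the scatter) and an at least 2.0-fold lower number from compound 1 to compound 2 (0.31 log units; beyond the scatter), and both turn on the 2-phenylethenyl group of compound 2, which compound 4 lacks. The third, a step that the two limits leave unreadable from compound 1 to compound 3, gives no size. Compound 4 is therefore expected to stay weak in this assay, near the limit reached by compound 3 at > 10000 nM. The expected step is a number no higher from compound 3 to compound 4 (the limit leaves the size open), and no change beyond the scatter is expected. For compound 4 the estimate is 10000 nM, with an expected range of 4000 nM to 25000 nM.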

Compound 4, half-maximal inhibitory concentration: 6400 nM
Compound 4: middle estimate off by 1.6-fold (0.19 log units), on the high side; the measured number falls inside the stated range.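

On this carbonyl carbon, a non-aromatic ring of carbon only now gives a measured number in this assay, so a measured number here no longer rests on the 2-phenylethenyl group alone. The comparison between the two measured compounds is a 1.3-fold higher number from compound 2 to compound 4 (0.12 log units; within the scatter), so the data do not separate these two groups. Against the two compounds that sit at a limit, the steps are an at least 1.5-fold lower number from compound 3 to compound 4 (0.19 log units; that floor lies within the scatter) and an at least 1.5-fold lower number from compound 1 to compound 4 (0.19 log units; that floor lies within the scatter), which are floors only, and their true sizes stay unknown: the limit of > 10000 nM in this assay, at which 2 of the 4 values shown sit.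

The compounds shown leave open whether the fluorines of the 4,4-difluorocyclohexyl group matter, which a plain cyclohexyl would test. They also leave open whether a group carrying an amine or a carboxylic acid on this carbonyl carbon would move the number beyond the scatter.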